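Methyl for Hydrogen on an Amide-Type Nitrogen: Series Notes

The source may report more compounds than this note shows. Statements on the series, on what has been measured and on what is new or still open speak of the compounds shown alone.

Measured so far:
Compound 1, `COC(=O)C[C@H](NC(=O)OC(C)(C)C)C(=O)NC1(C(=O)NCc2ccccc2)CCN(Cc2ccccc2)CC1`, gives 23000 nM in a functional assay on L1210 cells (Mus musculus) for inhibition, with a stated time of 48 h; a lower number here means a stronger inhibitor, a higher number a weaker inhibitor.
Compound 2, `COC(=O)C[C@H](NC(=O)OC(C)(C)C)C(=O)N(C)C1(C(=O)NCc2ccccc2)CCN(Cc2ccccc2)CC1`, gives 17000 nM in this assay.
Compound 3, `CC(C)(C)OC(=O)N[C@@H](CC(N)=O)C(=O)N(Cc1ccccc1)C1(C(=O)NCc2ccccc2)CCN(Cc2ccccc2)CC1`, gives 27000 nM in this assay.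

All three numbers sit close together. Among the compounds with values here, the one counted step among them is methyl in place of hydrogen on an amide-type nitrogen, which gave a 1.4-fold lower number from compound 1 to compound 2 (0.13 log units; within the scatter); the two values are within the scatter of each other, so no change in inhibition can be read from this pair. Compound 3 differs from compound 1 in more than one place, and the difference between the two cores is not broken down here; its value stands nearest to that of compound 1 and furthest from that of compound 2, both gaps within the scatter.

Compound 4, `CNC(=O)C[C@H](NC(=O)OC(C)(C)C)C(=O)N(Cc1ccccc1)C1(C(=O)NCc2ccccc2)CCN(Cc2ccccc2)CC1`, has not yet been measured in this assay. It differs from compound 3 by methyl in place of hydrogen on an amide-type nitrogen. Within the data shown here, this is the same kind of change as that from compound 1 to compound 2, though not the same: there the amide-type nitrogen had a carbonyl carbon and a saturated ring carbon as its other neighbours, whereas here its only other neighbour is a carbonyl carbon. Among the measured compounds shown here, the expectation rests on the single measured instance, a 1.4-fold lower number from compound 1 to compound 2 (0.13 log units; within the scatter), which was within the scatter. On that basis the step from compound 3 to compound 4 is expected to be small, about a 1.2-fold lower number from compound 3 to compound 4 (0.09 log units; within the scatter). For compound 4 the estimated value in this assay is 22000 nM, with a range from 9000 nM to 55000 nM.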

Compound 4, half-maximal inhibitory concentration: 94000 nM
Compound 4: middle estimate off by 4.3-fold (0.63 log units), on the low side, and the stated range ends below it.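

Methyl in place of hydrogen on an amide-type nitrogen gave a 3.5-fold higher number from compound 3 to compound 4 (0.54 log units; beyond the scatter) in this assay, a modest loss of inhibition on this core. The change therefore cannot be carried from one core to another in this series as a step of fixed size: the same change on two cores in this assay, a 1.4-fold lower number (0.13 log units; within the scatter) from compound 1 to compound 2 and a 3.5-fold higher number (0.54 log units; beyond the scatter) from compound 3 to compound 4, 4.7-fold (0.67 log units) apart, beyond the scatter of two such steps. Within the data shown here, this rests on a single pair for each core and shows only that the two steps differ, not why they differ; the nitrogen carrying the methyl also has a different set of neighbours in each pair, a carbonyl carbon and a saturated ring carbon in the earlier pair but only a carbonyl carbon in the later one, and these pairs cannot separate that difference from any other difference between the cores.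

The compounds shown leave open whether ethyl on the same nitrogen, or dimethylcarbamoyl in place of methylcarbamoyl, would extend the step seen on this core or leave it unchanged. They also leave open how a carboxylic acid at the end of the same side chain, in place of the carbamoyl group or the methyl ester, would read on either core.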